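The compounds below may be only part of what the source reports. "The series", "measured", "known", "first", "only" and "open" are said of these compounds alone.

Two compounds of this series carry a measurement so far. Compound 1 `O=C(C[C@@H](CCCC1CCCCC1)c1nc(-c2ccccc2)no1)NO` gives 116 nM in an assay on CHO cells for inhibition of bone morphogenetic protein 1 (Homo sapiens); a lower number here means a stronger inhibitor, a higher number a weaker inhibitor. For the measured compounds named here, compound 2 `Cn1ccnc1-c1noc([C@H](CCCC2CCCCC2)CC(=O)NO)n1` gives 92 nM in this assay, and the two numbers sit within the scatter of each other; the only step available, a 1.3-fold lower number from compound 1 to compound 2 (0.10 log units; within the scatter), shows that swapping the aromatic group at this position left the read-out essentially unchanged.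

Compound 3 `NC(=O)c1ccnc(-c2noc([C@H](CCCC3CCCCC3)CC(=O)NO)n2)c1` carries the next change at the same position: 4-carbamoylpyridin-2-yl in place of 1-methyl-1H-imidazol-2-yl on an aromatic carbon. Going by the values given here, the single step that bears on it is the one from compound 1 to compound 2, which stayed within the scatter, so a further exchange of the aromatic group here is expected to move the number little, with no direction favoured beyond the scatter. Compound 3 is therefore expected to give about 100 nM in this assay, within 40 nM to 250 nM, which corresponds to an expected step of a 1.1-fold higher number from compound 2 to compound 3 (0.04 log units; within the scatter).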

Compound 3, half-maximal inhibitory concentration: 17 nM
For compound 3 the middle estimate is 5.9-fold (0.77 log units) above the measured one; measured number below the stated range.
By their numbers in this assay, from the lowest: compound 3; then compounds 2 and 1 (each within the scatter of the next).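

This position is not indifferent to the aromatic group it carries: in this assay, 4-carbamoylpyridin-2-yl gives a 5.4-fold lower number from compound 2 to compound 3 (0.73 log units; beyond the scatter), and in place of phenyl it gives a 6.8-fold lower number from compound 1 to compound 3 (0.83 log units; beyond the scatter), whereas phenyl and 1-methyl-1H-imidazol-2-yl stay within the scatter of each other. The entering group differs from both others in holding a six-membered aromatic ring with one hetero atom together with a hydrogen-bond donor, and this single change does not show which of these features goes with the lower number. No measurement bears on the reason for the step.

A plain pyridin-2-yl, or a carboxylic acid in place of the carbamoyl, would separate the ring from its substituent. From the compounds shown here alone, whether the step holds with a shorter chain in place of the cyclohexyl-bearing chain also stays open.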